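Chain length and cell inhibition in an isothiocyanate series

This account rests on a few compounds, and the source may have more. Where it says the series, first, only, none or still open, it means among the compounds named here.

Four compounds share a core and differ in the chain that carries an isothiocyanate. Compound 1 is `CN(C)C(=O)c1cc2cnc(Nc3ccc(C(=O)NCCCN=C=S)cc3F)nc2n1C1CCCC1`, compound 2 is `CN(C)C(=O)c1cc2cnc(Nc3ccc(C(=O)NCCCCN=C=S)cc3F)nc2n1C1CCCC1`, compound 3 is `CN(C)C(=O)c1cc2cnc(Nc3ccc(NC(=O)CCCCCN=C=S)cc3)nc2n1C1CCCC1` and compound 4, not yet measured, is `CN(C)C(=O)c1cc2cnc(Nc3ccc(NC(=O)CCCCCCN=C=S)cc3)nc2n1C1CCCC1`. In a functional assay on A549 cells (Homo sapiens) for inhibition, read by CCK-8 assay, with a stated time of 72 h, tested at 1 uM (on this read-out higher numbers stand for a stronger effect at the one concentration tested and lower numbers for a weaker effect), compound 1 gives 16.7%, compound 2 gives -7% and compound 3 gives 56.1%.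

The change from compound 1 to compound 2 is a group of 4 heavy atoms (2 carbon, 1 nitrogen, 1 sulfur; no ring) in place of a group of 3 heavy atoms (1 carbon, 1 nitrogen, 1 sulfur; no ring), on a saturated chain carbon, three bonds along the chain from an amide-type nitrogen, and in this assay it made a number 23.7 percentage points lower from compound 1 to compound 2 (beyond the scatter). How the core of compound 3 differs from that of compound 1 is not broken down here.

Compound 4 arises from compound 3 by a group of 4 heavy atoms (2 carbon, 1 nitrogen, 1 sulfur; no ring) in place of a group of 3 heavy atoms (1 carbon, 1 nitrogen, 1 sulfur; no ring), on a saturated chain carbon, five bonds along the chain from a carbonyl carbon. This is the same kind of change, though the place differs: in one case three bonds along the chain from an amide-type nitrogen, in the other five bonds along the chain from a carbonyl carbon.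

Going by the values given here, for compound 4 a step of a number 18.1 percentage points lower from compound 3 to compound 4 (beyond the scatter) is expected, mainly because a number 23.7 percentage points lower from compound 1 to compound 2 (beyond the scatter) is the only measured example of this kind of change. In this assay compound 4 is therefore estimated at 38%, within a range from 12% to 62%.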

Compound 4, a percentage reported as inhibition, at one concentration (the size of the read-out at that concentration, not a potency): 43.3%
The estimate for compound 4 lay 5.3 percentage points below the measured number; the range from low to high includes it.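

On the core of compound 3, putting the group of 4 heavy atoms in place of the group of 3 heavy atoms again lowered the result in this assay, giving a number 12.8 percentage points lower from compound 3 to compound 4 (beyond the scatter). The change therefore went in the same direction on both cores, and the sizes of the two steps cannot be told apart: the same change on two cores in this assay, a number 23.7 percentage points lower (beyond the scatter) from compound 1 to compound 2 and a number 12.8 percentage points lower (beyond the scatter) from compound 3 to compound 4, 10.9 percentage points apart, within the scatter of two such steps. Going by these compounds alone, this suggests that the effect of the change carries over between these two cores, but it rests on only two pairs of compounds, so it does not establish a rule for other cores or other chain lengths, and it does not explain why the number falls.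

On these data alone, it remains open whether a longer chain on either core would lower the number further, and whether an amine or a carboxylic acid in place of the isothiocyanate would keep any of the effect. Also open, as far as these compounds go, is how these steps would look across a range of concentrations, as each number here describes the effect at one concentration and is not a potency.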